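The compounds below may be only part of what the source reports. "The series", "measured", "known", "first", "only" and "open" are said of these compounds alone.

Measured compounds:
- compound 1, `COc1ccccc1NC(=O)CCCCCCNC(=O)C(O)(O)C(F)(F)F`, 10100 nM
- compound 2, `COc1ccc(OC)c(NC(=O)CCCCCCNC(=O)C(O)(O)C(F)(F)F)c1`, 3870 nM
- compound 3, `Cc1nc(NC(=O)CCCCCCNC(=O)C(O)(O)C(F)(F)F)sc1-c1ccccc1`, 10100 nM

In a functional assay on HCT-116 cells (Homo sapiens) for inhibition, read by colorimetric assay, with a stated time of 3 days (on this read-out higher numbers stand for weaker inhibition and lower numbers for stronger inhibition), compound 1 gives 10100 nM. This stands level with compound 3, which gives 10100 nM; together they are the two highest numbers of the three. For the measured compounds named here, compound 2 is the furthest away, and the only measured step, a 2.6-fold lower number from compound 1 to compound 2 (0.42 log units; beyond the scatter), goes with a methoxy in place of hydrogen on an aromatic carbon.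

Compound 4, `O=C(CCCCCCNC(=O)C(O)(O)C(F)(F)F)Nc1c(F)cc(F)cc1F`, has not yet been measured. It differs from compound 1 as follows: 2,4,6-trifluorophenyl in place of 2-methoxyphenyl on an amide-type nitrogen. Going by the values given here, no measured pair shows a change of this kind; the one measured step adds a methoxy rather than exchanging the whole aryl group, so it bears on the question only loosely. With nothing pointing clearly either way, the expected step in this assay, a 1.1-fold lower number from compound 1 to compound 4 (0.05 log units; within the scatter), is within the scatter. Compound 4 is therefore estimated at 9000 nM in this assay, with a range from 3000 nM to 30000 nM.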

Compound 4, half-maximal inhibitory concentration: 22200 nM
For compound 4 the middle estimate is 2.5-fold (0.39 log units) below the measured one; low and high end bracket the measured number.
By their numbers in this assay, from the lowest: compound 2; then compounds 1 and 3 (each within the scatter of the next); then compound 4.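

In this assay the aryl group on the amide-type nitrogen can move the number upward as well as downward: a 2.2-fold higher number from compound 1 to compound 4 (0.34 log units; beyond the scatter) goes with 2,4,6-trifluorophenyl in place of 2-methoxyphenyl. The earlier step on this aryl group, a 2.6-fold lower number from compound 1 to compound 2 (0.42 log units; beyond the scatter), ran the other way with an added methoxy. The exchange removes the methoxy and brings in three fluorines at once, so the result cannot assign the higher number to either part of the change, and no supporting measurement accounts for it.

Still open, going by these compounds, is how a plain phenyl or a single fluorine on the phenyl ring would compare on this amide-type nitrogen. The compounds shown also leave open whether a pyridyl group in place of the aryl group, or a longer chain in the shared core, would shift the number.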